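The source may hold more compounds than are shown below. What is called first, only, known or untested is meant among the compounds shown, and "the series" means these compounds.

Compound 2 `CCN(CC)c1cc2[nH]c(C3CCCCC3)nc2cc1NC(=O)c1ccc(OC(F)(F)F)cc1` was tested in an ADME assay on Vero cells (Chlorocebus sabaeus) for cytotoxicity, read by resazurin assay, with a stated time of 3 days; a lower number here means a stronger inhibitor, a higher number a weaker inhibitor. In this assay compound 2 gives > 100 ug/mL, which is a limit of the assay rather than a number. Compound 1 `CCN(CC)c1cc2[nH]c(C3CCCCC3)nc2cc1NC(=O)OCC(F)(F)F` gives > 100 ug/mL in this assay, again a limit. Within the data shown here, the only measured step, a step that the two limits leave unreadable from compound 1 to compound 2, is therefore unreadable in size and direction, as the limit of > 100 ug/mL in this assay, at which 2 of the 2 values shown sit, records. Compound 3 `CCN(CC)c1cc2[nH]c(C3CCCCC3)nc2cc1NC(=O)c1ccc(C)cc1` differs from compound 2 by methyl in place of trifluoromethoxy on an aromatic carbon. Among the measured compounds shown here, no measured step bears on this change, so nothing beyond the scatter is expected. Compound 3 is estimated at 150 ug/mL, ranging from 60 ug/mL to 400 ug/mL. The expected step is a step that the limit leaves unreadable from compound 2 to compound 3.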

Compound 3, half-maximal inhibitory concentration: > 100 ug/mL
Compound 3 ended at the assay's limit; the forecaster's own chance of this, stated with the estimate: 75%; the middle value does not contradict the limit.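

Compound 3 sits at a limit of this assay, as do compound 1 and compound 2, so none of the steps among them can be read: the limit of > 100 ug/mL in this assay, at which 3 of the 3 values shown sit.

Going by these compounds, whether these compounds differ at all in this assay stays open.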